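This account rests on a few compounds, and the source may have more. Where it says the series, first, only, none or still open, it means among the compounds named here.

Compound 1 `COc1cc(C)cc(-c2c(-c3ccnc(-c4ccc(C(C)=O)cc4)c3)cnn2CC#N)c1` was examined in a functional assay on NCI-H322M cells (Homo sapiens) for inhibition, read by sulforhodamine B assay, with a stated time of 48 h; on this read-out lower numbers stand for higher toxicity in this test and higher numbers for lower toxicity in this test. In this assay compound 1 gives > 100000 nM, which is a limit of the assay rather than a number. Compound 2 `COc1cc(C)cc(-c2nn(CC#N)cc2-c2ccc(-c3cccc(C(C)=O)c3)nc2)c1` likewise reaches only a limit in this assay, giving > 100000 nM. Compound 3 `Cc1cc(O)cc(-c2nn(CC#N)cc2-c2ccnc(-c3ccc(N(C)C)cc3)c2)c1` also stands at a limit in this assay, with > 100000 nM. All three values share (the limit of > 100000 nM in this assay, at which 3 of the 3 values shown sit). The step considered leads to compound 4 `COc1cc(C)cc(-c2c(-c3ccnc(-c4ccc(N(C)C)cc4)c3)cnn2CC#N)c1`, with dimethylamino in place of acetyl on an aromatic carbon. Within the data shown here, no step between measured compounds is available; the only guide is compound 3, which carries the same dimethylamino group and gives > 100000 nM. Compound 4 is therefore expected to show no step beyond the scatter, a step that the limit leaves unreadable from compound 1 to compound 4. The estimate for compound 4 is 150000 nM, within 50000 nM to 500000 nM, most probably again only a limit.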

Compound 4, concentration lethal to 50% of the cells: > 100000 nM
Compound 4: no number, only a limit; the forecaster's own chance of this, stated with the estimate: 85%; the middle value is on the limit's open side.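

Compound 4 gives > 100000 nM in this assay, which is a limit and not a number. Compound 1 also stands at a limit, so no step can be read between compound 1 and compound 4. The compounds shown leave open which change, if any, would give a readable number: the limit of > 100000 nM in this assay, at which 4 of the 4 values shown sit.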